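The source may report more compounds than this note shows. Statements on the series, on what has been measured and on what is new or still open speak of the compounds shown alone.

Measured so far:
Compound 1 `CCCC#Cc1ccc(-c2cc3cn([C@H]4C[C@H](O)[C@@H](CO)O4)c(=O)nc3o2)cn1`: > 50000 nM
Compound 2 `CCCCCc1ccc(CCc2cc3cn([C@H]4C[C@H](O)[C@@H](CO)O4)c(=O)nc3o2)cc1`: > 470000 nM

In an ADME assay on HEL cells (Homo sapiens) for cytotoxicity, with a stated time of 3 days (on this read-out lower numbers stand for higher toxicity in this test and higher numbers for lower toxicity in this test), compound 1 gives only a limit of the test, > 50000 nM. Compound 2 also gives only a limit, > 470000 nM. Neither of these is a number, so compound 1 cannot be placed above or below compound 2 on what is known. Compound 3 `CCCCCCc1ccc(-c2cc3cn([C@H]4C[C@H](O)[C@@H](CO)O4)c(=O)nc3o2)cn1` has not yet been measured; it differs from compound 1 by hexyl in place of pent-1-yn-1-yl on an aromatic carbon. Going by the values given here, with no measured step between compounds to lean on, the expected step that the limit leaves unreadable from compound 1 to compound 3 is none beyond the scatter, and a limit is the most likely report again. Compound 3 is estimated at 60000 nM, between 25000 nM and 300000 nM.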

Compound 3, half-maximal cytotoxic concentration: > 50000 nM
Compound 3: only a limit was reported; the forecaster's own chance of this, stated with the estimate: 80%; the middle value does not contradict the limit.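

Compound 1 and compound 3 each gave only a limit of the test, so no step can be read between them. The compounds shown leave open whether hexyl in place of pent-1-yn-1-yl changes the result in this assay at all.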